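Fluoro for methyl on the benzamide ring

This account rests on a few compounds, and the source may have more. Where it says the series, first, only, none or still open, it means among the compounds named here.

Measured so far:
compound 1 `Cc1ccc(C(=O)Nc2ccc(CNC(=O)OCc3cccnc3)cc2)c(N2CCCC2)c1` gives 1870 nM
compound 2 `O=C(NCc1ccc(NC(=O)c2cc(Cl)ccc2N2CCCC2)cc1)OCc1cccnc1` gives 750 nM
compound 3 `O=C(NCc1ccc(NC(=O)c2cc(C(F)(F)F)ccc2N2CCCC2)cc1)OCc1cccnc1` gives 790 nM

In a functional assay on HGC-27 cells (Homo sapiens) for inhibition, read by MTT assay, with a stated time of 72 h (on this read-out lower numbers stand for stronger inhibition and higher numbers for weaker inhibition), compound 1 gives the highest number of the three; compound 2 and compound 3 both sit beyond the scatter below it. Compound 4 `O=C(NCc1ccc(NC(=O)c2ccc(F)cc2N2CCCC2)cc1)OCc1cccnc1` arises from compound 1 by a single change (fluoro in place of methyl on an aromatic carbon). Among the measured compounds shown here, no measured step matches this change: compound 2 and compound 3 each differ from compound 1 in more than one place, and the only single step, a 1.1-fold higher number from compound 2 to compound 3 (0.02 log units; within the scatter), exchanges two other groups. A small halogen for methyl on the same carbon is therefore expected to give, at most, a modest step in this assay, direction uncertain. Compound 4 is estimated at 1300 nM, range 500 nM to 3500 nM, a step of a 1.4-fold lower number from compound 1 to compound 4 (0.16 log units; within the scatter).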

Compound 4, half-maximal inhibitory concentration: 1840 nM
Estimate against measurement, compound 4: 1.4-fold (0.15 log units) below; the range from low to high includes it.
By their numbers in this assay, from the lowest: compounds 2 and 3 (each within the scatter of the next); then compounds 4 and 1 (each within the scatter of the next).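

In this assay, fluoro in place of methyl on this aromatic carbon, meta to a pyrrolidin-1-yl group and para to a large group, gives a 1.0-fold lower number from compound 1 to compound 4 (0.01 log units; within the scatter). Among the compounds shown here, this is the first single change read at this position, so the read-out here does not separate methyl from fluoro. No measured data bear on why the two groups read alike. As far as these compounds go, whether a carboxylic acid or a dimethylamino group on this carbon would give a step beyond the scatter remains open. Also open, from the compounds shown here alone, is whether the same exchange reads alike on a core without the pyrrolidin-1-yl group.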